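Swapping the sulfonamide aryl group: an expected loss

A few compounds are considered here, and "the series" means these few. Any claim that something is new, unique, unknown or untested is made for them only; others in the source may bear on it.

Compound 1, `COc1ccc(S(=O)(=O)N2CCC(CCC(=O)c3cc(Cl)c(N)cc3OC)CC2)cc1`: "not active" (no number reported)
Compound 2, `COc1ccc(S(=O)(=O)NCCCN2CCC(CCC(=O)c3cc(Cl)c(N)cc3OC)CC2)cc1`: "not active" (no number reported)
Compound 3, `COc1cc(N)c(Cl)cc1C(=O)CCC1CCN(CCNS(=O)(=O)c2cc(Br)c(N)c(Br)c2)CC1`: 52%

Of the compounds shown here, three sharing a common core have been tested in an assay on HEK293 cells for displacement of a labelled ligand from 5-hydroxytryptamine receptor 6 (Homo sapiens), with a stated time of 60 min, tested at 0.01 uM, in the presence of a further agent that is not named here; on this read-out higher numbers stand for a stronger effect at the one concentration tested and lower numbers for a weaker effect. Compound 1 gives "not active" (no number reported) and compound 2 gives "not active" (no number reported), both reported without a figure. Going by the values given here, compound 3 gives 52% in this assay, the only number among the three, so it is the single point of reference here.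

Compound 4, `COc1ccc(S(=O)(=O)NCCN2CCC(CCC(=O)c3cc(Cl)c(N)cc3OC)CC2)c(OC)c1`, has not been measured. It differs from compound 3 in one place: 2,4-dimethoxyphenyl in place of 4-amino-3,5-dibromophenyl on a sulfonyl sulfur. The change sits on the sulfonyl sulfur that is bound to the sulfonamide nitrogen.

Among the compounds with values here, no step between measured compounds is available, so the expectation rests on the three values alone. Within the data shown here, compounds 1 and 2, which carry a methoxy-bearing aryl group on their sulfonyl sulfur, are both without activity, while compound 3 with its 4-amino-3,5-dibromophenyl is the only one with a number. The step of a number 34 percentage points lower from compound 3 to compound 4 (beyond the scatter) is therefore expected to run downward, beyond the usual scatter. Compound 4 is estimated to give 18%, within a range of 0% to 42%.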

Compound 4, a percentage reported as inhibition, at one concentration (the size of the read-out at that concentration, not a potency): "not active" (no number reported)
Compound 4: no number reported, so the estimate cannot be set against anything.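

Going by these compounds alone, compound 4 gives "not active" (no number reported), so, with no figure to set against compound 3, no step between the two can be read. From the compounds shown here alone, what remains open is how much of the effect of compound 3 goes with its 4-amino-3,5-dibromophenyl. No measurement shown here helps to explain this result.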